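Swapping an aryl for a phenethyl on a thiourea-acyl

A few compounds are considered here, and "the series" means these few. Any claim that something is new, unique, unknown or untested is made for them only; others in the source may bear on it.

Of the compounds shown here, two of a shared core have been tested in an ADME assay on Huh-7 cells (Homo sapiens) for cytotoxicity; a higher number here means that more compound is tolerated, a lower number that less compound is tolerated. Compound 1, `O=C(NC(=S)N1CCc2c(OCc3ccccc3)cccc21)c1ccccc1`, returns only a limit of this assay, > 50000 nM, because of the limit of > 50000 nM in this assay, at which 1 of the 2 values shown sits. Compound 2, `O=C(NC(=S)N1CCc2c(OCCCCCOc3ccc(Cl)cc3)cccc21)c1ccc([N+](=O)[O-])cc1`, gives 13600 nM in this assay. Among the compounds with values here, that figure is the only measured number in the set; the other entry is a limit, so nothing can be said about the order of the two compounds.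

Compound 3, `O=C(CCc1ccccc1)NC(=S)N1CCc2c(OCCCCCOc3ccc(Cl)cc3)cccc21`, has not yet been measured in this assay. It differs from compound 2 in one place: phenethyl in place of 4-nitrophenyl on a carbonyl carbon. Within the data shown here, no measured pair with this kind of change is available, so the size of the step rests on expectation alone. The step from compound 2 to compound 3 is expected to be small, a 1.5-fold higher number from compound 2 to compound 3 (0.17 log units; within the scatter), and may well lie within the usual scatter. Compound 3 is therefore estimated at 20000 nM in this assay, with a range from 7000 nM to 50000 nM; a reading that is only a limit is also possible.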

Compound 3, half-maximal cytotoxic concentration: > 50000 nM
Compound 3: a limit, no number (the forecaster's own chance of this, stated with the estimate: 30%); middle value at least 2.5-fold (0.39 log units) away from the limit.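

Within the data shown here, with phenethyl in place of 4-nitrophenyl on a carbonyl carbon, this assay shows an at least 3.6-fold higher number from compound 2 to compound 3 (0.56 log units; beyond the scatter), and this is the first step in the set that can be read. Among these compounds, compound 1 and compound 2 differ in more than one place and offered no step, leaving it unknown whether the group at this position could shift the reading at all; the change here shows that it can, by more than the scatter. The reading for compound 3 is a limit of the assay, which means the step has a lower bound and no upper one: the limit of > 50000 nM in this assay, at which 2 of the 3 values shown sit.

The compounds shown leave open which part of the swap carries the step, the loss of the nitro group or the ethylene link to the phenyl ring, a question that an unsubstituted phenyl or a 4-nitrophenethyl on this carbonyl carbon, with the rest of compound 2 kept, would help to settle. Also open, on these data alone, is how other groups at this position would read, such as a 4-aminophenyl, a 4-carboxyphenyl or a longer phenylalkyl chain.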